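A few compounds are considered here, and "the series" means these few. Any claim that something is new, unique, unknown or untested is made for them only; others in the source may bear on it.

Compound 1 `CCOC(=O)NC(=O)NC1=CS(=O)(=O)O[C@@]12[C@@H](CO[Si](C)(C)C(C)(C)C)O[C@@H](n1cc(C)c(=O)n(C)c1=O)[C@@H]2O[Si](C)(C)C(C)(C)C` is the reference point of this set. In a functional assay on HEL cells (Homo sapiens) (on this read-out higher numbers stand for lower toxicity in this test and lower numbers for higher toxicity in this test), compound 1 gives 14000 nM, the lowest of the two plain numbers recorded. Its nearest neighbour is compound 2 `COC(=O)CC(=O)NC1=CS(=O)(=O)O[C@@]12[C@@H](CO[Si](C)(C)C(C)(C)C)O[C@@H](n1cc(C)c(=O)n(C)c1=O)[C@@H]2O[Si](C)(C)C(C)(C)C`, which in this assay gives 29000 nM, so that a 2.1-fold higher number from compound 1 to compound 2 (0.32 log units; beyond the scatter). Compound 3 `COC(=O)C(=O)CNC1=CS(=O)(=O)O[C@@]12[C@@H](CO[Si](C)(C)C(C)(C)C)O[C@@H](n1cc(C)c(=O)n(C)c1=O)[C@@H]2O[Si](C)(C)C(C)(C)C` reaches only a limit of this assay, > 200000 nM. Measured against that limit, an at least 14-fold higher number from compound 1 to compound 3 (1.15 log units; beyond the scatter), and an at least 6.8-fold higher number from compound 2 to compound 3 (0.83 log units; beyond the scatter); these two steps rest on (the limit of > 200000 nM in this assay, at which 1 of the 3 values shown sits).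

Compound 4 `Cc1cn([C@@H]2O[C@H](CO[Si](C)(C)C(C)(C)C)[C@@]3(OS(=O)(=O)C=C3NCCC(=O)OCc3ccccc3)[C@H]2O[Si](C)(C)C(C)(C)C)c(=O)n(C)c1=O` is not yet measured. Its change from compound 1 is 2-(benzyloxycarbonyl)ethyl in place of (ethoxycarbonyl)carbamoyl on an amine nitrogen. All three measured steps alter the same attachment on the amine nitrogen, and each raised the number, the largest when an acyl-type substituent gave way to a plain carbon chain, as in compound 3. Compound 4 likewise carries a carbon chain there, so a clearly higher number is expected, a 7.1-fold higher number from compound 1 to compound 4 (0.85 log units; beyond the scatter). Compound 4 is therefore estimated at 100000 nM, within 30000 nM to 300000 nM.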

Compound 4, half-maximal cytotoxic concentration: 200000 nM
For compound 4 the middle estimate is 2.0-fold (0.30 log units) below the measured one; low and high end bracket the measured number.
By their numbers in this assay, from the lowest: compound 1; then compound 2; then compound 4.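

Going by these compounds alone, with compound 4, a saturated carbon chain on the amine nitrogen gets a plain number in this assay for the first time, so the size of the change can be read: a 14-fold higher number from compound 1 to compound 4 (1.15 log units; beyond the scatter), and a 6.9-fold higher number from compound 2 to compound 4 (0.84 log units; beyond the scatter). The number stays high even though 2-(benzyloxycarbonyl)ethyl is the larger group and brings a six-membered aromatic ring of carbon only, which neither group it replaces in compound 1 or compound 2 carries. The remaining step, a number no higher from compound 3 to compound 4 (the limit leaves the size open), cannot be read: the limit of > 200000 nM in this assay, at which 1 of the 4 values shown sits.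

The compounds shown leave open whether the benzyl ester of compound 4 contributes to this number, or whether the chain alone accounts for it. A free carboxylic acid or an amine at the end of the chain, or a longer chain, could separate these two readings.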